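A few compounds are considered here, and "the series" means these few. Any claim that something is new, unique, unknown or untested is made for them only; others in the source may bear on it.

Compound 1 `CCSc1nc(N)c2nc(O)n(Cc3ccccc3)c2n1` stands at the lowest number of the three measured in a functional assay (spleen, spleen) for activation, with Mus musculus as the target (on this read-out higher numbers stand for an effect only at larger amounts of compound and lower numbers for an effect already at smaller amounts), where compound 1 gives 0.1 uM. Compound 2 `Nc1ncnc2c1nc(O)n2Cc1cccc2ccccc12` gives 10 uM in this assay, and compound 3 `Nc1ncnc2c1nc(S)n2Cc1ccccc1` gives 10 uM in this assay; both of these sit well beyond the usual scatter above compound 1. The unmeasured compound 4 `CCCNc1nc(N)c2nc(O)n(Cc3ccccc3)c2n1` differs from compound 1 in one place: propylamino in place of ethylsulfanyl on an aromatic carbon. Among the measured compounds shown here, no pair of measured compounds differs in just that way, and the two other measured compounds differ from compound 1 at other places, so nothing measured shows directly what this swap does. For the measured compounds named here, the change touches only that one group and leaves the rest of the core of compound 1 as it is. A modest step in this assay is expected, more probably toward a somewhat higher number, though a result within the scatter would not surprise. The step from compound 1 to compound 4 is expected to be a 3.0-fold higher number from compound 1 to compound 4 (0.48 log units; beyond the scatter). Compound 4 is estimated at 0.3 uM in this assay, with a range from 0.05 uM to 2 uM.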

Compound 4, minimum effective concentration: 0.1 uM
Beside the measured number, compound 4's estimate is 3.0-fold (0.48 log units) above it; measured number inside the range.
By their numbers in this assay, from the lowest: compounds 1 and 4 (each within the scatter of the next); then compounds 2 and 3 (each within the scatter of the next).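

In this assay, placing propylamino where ethylsulfanyl stood gives no change at the digits printed from compound 1 to compound 4 (within the scatter). For this pair, the sulfur link on the aromatic carbon between two ring nitrogen atoms is therefore not needed to keep the effect at the same amount of compound: a nitrogen link, one more heavy atom and a hydrogen-bond donor all enter without a visible shift. Nothing available explains why the swap leaves the read-out in place.

The compounds shown leave open how far this tolerance extends, for instance to an oxygen-linked butoxy group, a longer pentylamino chain or a ring-bearing benzylamino group. They also leave open whether propylamino would behave the same way if the benzyl group on the shared core were replaced.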